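This account rests on a few compounds, and the source may have more. Where it says the series, first, only, none or still open, it means among the compounds named here.

In a functional assay on the whole organism (strain albino) for inhibition, with Rattus norvegicus as the target, read by paw edema, with stated times of 1 h and 3 h, at a dose of 25 mg/kg by the oral route (a higher number here means more inhibition at the dose given (going by the name of the read-out), a lower number less inhibition), compound 1 `CC1=C(C(=O)Nc2ccc(F)cc2)C(c2ccc([N+](=O)[O-])cc2)n2c(s/c(=C/c3ccc(Cl)cc3)c2=O)=N1` gives 23%, and compound 2 `COc1ccc(/C=c2/sc3n(c2=O)C(c2ccc([N+](=O)[O-])cc2)C(C(=O)Nc2ccc(F)cc2)=C(C)N=3)cc1` gives 12%. Going by the values given here, compound 2 thus stands lowest of the two numbers in this assay, its nearest neighbour being compound 1, reached by the single step of a number 11 percentage points lower from compound 1 to compound 2 (beyond the scatter). The next compound, compound 3 `CC1=C(C(=O)Nc2ccc(F)cc2)C(c2ccc([N+](=O)[O-])cc2)n2c(s/c(=C/c3ccccc3Cl)c2=O)=N1`, differs from compound 2 in one place: 2-chlorophenyl in place of 4-methoxyphenyl on a double-bonded chain carbon bound to an aromatic carbon. Among the compounds with values here, the only measured step that bears on this change is the one from compound 1 to compound 2, in which methoxy replaced chloro and the number fell by a modest amount beyond the scatter. Compound 3 brings chloro back, though the group that enters is 2-chlorophenyl rather than the 4-chlorophenyl of compound 1, so the return is expected to be partial. Compound 3 is therefore expected to rise by a number 8 percentage points higher from compound 2 to compound 3 (within the scatter) in this assay. The estimated value of compound 3 is 20%, within a range from 8% to 32%.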

Compound 3, a percentage reported as inhibition, in the whole organism at one dose (the size of the read-out at that dose, not a potency): 19%
The estimate for compound 3 lay 1 percentage points above the measured number; low and high end bracket the measured number.
By their numbers in this assay, from the lowest: compounds 2, 3 and 1 (each within the scatter of the next, the first and the last beyond it).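

In this assay, the 2-chlorophenyl group of compound 3 cannot be told apart from either earlier group on the double-bonded chain carbon: in place of 4-methoxyphenyl it gives a step within the scatter (a number 7 percentage points higher from compound 2 to compound 3 (within the scatter)), and in place of 4-chlorophenyl it does the same (a number 4 percentage points lower from compound 1 to compound 3 (within the scatter)). Compounds 1 and 2 alone had shown only a gap beyond the scatter between the two 4-substituted phenyl groups, whereas compound 3 lies within the scatter of both, so moving the chlorine on this ring leaves no readable mark at this dose. Nothing at hand explains these numbers.

The compounds shown leave open how a phenyl group carrying an amine or a carboxylic acid would read at this place. They also leave open whether a longer chain between this carbon and the ring would shift the number beyond the scatter.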